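Swapping diethylamino for piperidin-1-yl on a shared core

The compounds below may be only part of what the source reports. "The series", "measured", "known", "first", "only" and "open" are said of these compounds alone.

Measured so far in a functional assay on A2780 cells (Homo sapiens) for inhibition (on this read-out higher numbers stand for weaker inhibition and lower numbers for stronger inhibition), for this small series:
Compound 1 `C=CNCc1cc(-c2c(C(=O)NCC)noc2-c2cc(C(C)C)c(O)cc2O)on1` gives 43 nM as its value
Compound 2 `CCNC(=O)c1noc(-c2cc(C(C)C)c(O)cc2O)c1-c1cc(CNC(=O)CC)no1` has "not determined" (no result reported) as its entry
Compound 3 `CCNC(=O)c1noc(-c2cc(C(C)C)c(O)cc2O)c1-c1cc(CN(CC)CC)no1` gives 78 nM as its value

Going by the values given here, compound 3 has only one measured neighbour to stand against. Its value and that of compound 1 lie within the scatter of each other, and compound 2 offers no number for comparison. The unmeasured compound 4 `CCNC(=O)c1noc(-c2cc(C(C)C)c(O)cc2O)c1-c1cc(CN2CCCCC2)no1` carries piperidin-1-yl in place of diethylamino on a saturated chain carbon bound to an aromatic carbon, and the rest of compound 3 is kept. The whole difference reads piperidin-1-yl in place of diethylamino on a saturated chain carbon bound to an aromatic carbon and touches nothing else in the structure.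

Among the compounds with values here, the one measured step at that same place is a 1.8-fold higher number from compound 1 to compound 3 (0.26 log units; within the scatter) and it exchanged vinylamino for diethylamino. This single pair is thin evidence, yet the change of group there stayed within the scatter in this assay and gives no direction to carry over. No step beyond the scatter is therefore expected for the new exchange. The estimated step is a 1.1-fold lower number from compound 3 to compound 4 (0.05 log units; within the scatter) and it is expected to stay small. The estimated value for compound 4 is 70 nM with an expected range from 30 nM to 160 nM in this read-out.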

Compound 4, half-maximal inhibitory concentration: 62 nM
Beside the measured number, compound 4's estimate is 1.1-fold (0.05 log units) above it; measured number inside the range.
By their numbers in this assay, from the lowest: compounds 1, 4 and 3 (each within the scatter of the next).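

Placing a ring at this position changes little: in this assay, piperidin-1-yl in place of diethylamino gives a 1.3-fold lower number from compound 3 to compound 4 (0.10 log units; within the scatter), and piperidin-1-yl in place of vinylamino gives a 1.4-fold higher number from compound 1 to compound 4 (0.16 log units; within the scatter). Before this result, the position rested on a single pair of open-chain amino groups; now a six-membered non-aromatic ring on the same saturated chain carbon also stays within the scatter of both, so none of the three measured amino groups separates from the others in this assay. Nothing available bears on why these exchanges leave the number so little changed.

The compounds shown leave open whether a group of another kind at this place, such as a carboxylic acid or a morpholine ring, would produce a step beyond the scatter, since all three measured groups are attached through an amine nitrogen. Steps involving compound 2 cannot be read, so its propanamide-type side chain says nothing yet about an amide at this position, and the rest of the shared core stays unexplored here.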